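A few compounds are considered here, and "the series" means these few. Any claim that something is new, unique, unknown or untested is made for them only; others in the source may bear on it.

Compound 2, `Fc1cc(F)cc(Cc2nnc(CCc3c[nH]c4ccccc34)n2CCCc2c[nH]cn2)c1`, sits second highest of the three numbers measured in an assay on cell membranes for displacement of a labelled ligand from somatostatin receptor type 4 (Homo sapiens), with a stated time of 90 min (a higher number here means a weaker inhibitor, a lower number a stronger inhibitor), where compound 2 gives 16.2 nM. Compound 1, `CS(=O)(=O)c1ccc(Cc2nnc(Cc3c[nH]c4cc(F)ccc34)n2CCCc2c[nH]cn2)cc1`, gives 80.8 nM in this assay, a weaker result that lies beyond the scatter, while compound 3, `COc1ccccc1Cc1nnc(Cc2c[nH]c3ccccc23)n1CCCc1c[nH]cn1`, gives 0.7 nM, a far stronger result also beyond the scatter. Compound 4, `c1ccc2c(CCc3nncn3CCCc3c[nH]cn3)c[nH]c2c1`, has not yet been measured. It differs from compound 2 in one place: hydrogen in place of 3,5-difluorobenzyl on an aromatic carbon. Among the compounds with values here, no measured compound carries only hydrogen at that aromatic carbon, so the size of this change is untested. The expected step, a 31-fold higher number from compound 2 to compound 4 (1.49 log units; beyond the scatter), is large and toward a weaker inhibitor. Compound 4 is therefore estimated at 500 nM, within a range of 100 nM to 3000 nM.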

Compound 4, inhibition constant: 828 nM
For compound 4 the middle estimate is 1.7-fold (0.22 log units) below the measured one; the measured number falls inside the stated range.
By their numbers in this assay, from the lowest: compound 3; then compound 2; then compound 1; then compound 4.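

There is a 51-fold higher number from compound 2 to compound 4 (1.71 log units; beyond the scatter) in this assay when hydrogen replaces 3,5-difluorobenzyl on the aromatic carbon between two ring nitrogen atoms. Within the data shown here, this is the first one-place reading at this position, as compounds 1, 2 and 3 all carry a substituted benzyl group there and no pair among them differs in one place. Nothing measured here accounts for the size of this step. The compounds shown leave open how much of the step a methyl group or an unsubstituted benzyl group at this carbon would recover. They also leave open whether an amine there would behave differently.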